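This account rests on a few compounds, and the source may have more. Where it says the series, first, only, none or still open, it means among the compounds named here.

Going by the values given here, compound 3 `NS(=O)(=O)c1cccc(-c2nc(C(c3ccc(F)cc3)c3ccc(F)cc3)sc2CC(=O)O)c1` is one of three compounds measured in an in vitro functional assay on HEK285-7 cells for antagonist activity at prostaglandin D2 receptor 2 (Homo sapiens), read by BRET and beta-arrestin recruitment; on this read-out higher numbers stand for weaker inhibition and lower numbers for stronger inhibition. In this assay compound 3 gives 710 nM. Compound 1 `O=C(O)Cc1sc(COc2ccc(Cl)cc2)nc1-c1ccc(Cl)cc1` gives 370 nM, a number within the usual scatter of that of compound 3, so these two cannot be told apart. Compound 2 `O=C(O)Cc1sc(C(c2ccccc2)c2ccc(Cl)cc2)nc1-c1ccc(Cl)cc1` gives 75 nM, a lower number beyond the scatter, so compound 2 is the stronger inhibitor of that pair. Compound 4 `O=C(O)Cc1sc(C(c2ccc(F)cc2)c2ccc(F)cc2)nc1-c1cc(F)nc(F)c1` has not yet been measured; it differs from compound 3 in one place: 2,6-difluoropyridin-4-yl in place of 3-sulfamoylphenyl on an aromatic carbon. Among the compounds with values here, no measured pair shows this change, so the size of the step is open. Compound 4 is expected to give a somewhat lower number, the estimated step being a 2.4-fold lower number from compound 3 to compound 4 (0.37 log units; beyond the scatter). The estimate for compound 4 is 300 nM, with a range from 80 nM to 1200 nM.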

Compound 4, half-maximal inhibitory concentration: 110 nM
The estimate for compound 4 lay 2.7-fold (0.44 log units) above the measured number; low and high end bracket the measured number.
By their numbers in this assay, from the lowest: compounds 2 and 4 (each within the scatter of the next); then compounds 1 and 3 (each within the scatter of the next).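

Putting 2,6-difluoropyridin-4-yl in place of 3-sulfamoylphenyl on this aromatic carbon gives a 6.5-fold lower number from compound 3 to compound 4 (0.81 log units; beyond the scatter) in this assay. Going by these compounds alone, this is the first direct look at this position, and it shows that a change here alone can move the number beyond the scatter. The entering group has no hydrogen-bond donor, so such a donor at this position is not needed for this level of inhibition, and nothing measured here explains the gain. Going by these compounds, the step changes the ring atoms and the substituents together, so their separate shares stay unknown. A plain pyridin-4-yl, without the fluorines, would begin to separate them.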